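Methyl on the phenyl group of compound 3

This account rests on a few compounds, and the source may have more. Where it says the series, first, only, none or still open, it means among the compounds named here.

compound 1 `CC1=NN(C(=O)CBr)C(c2ccccc2O)C1` gives 4180 nM
compound 2 `CC1=NN(C(=O)CCl)C(c2cc(Br)ccc2O)C1` gives 9210 nM
compound 3 `CC1=NN(S(=O)(=O)c2ccccc2)C(c2cc(Br)ccc2O)C1` gives 55600 nM

All three values come from a functional assay on SGC-7901 cells (Homo sapiens) for antiproliferative activity, read by MTT assay, with a stated time of 48 h (a higher number here means that more compound is needed for the effect, a lower number that less compound is needed), and they spread widely. Compound 3 at 55600 nM has the highest number of the three. Compound 2 at 9210 nM is its nearest neighbour and compound 1 at 4180 nM is the furthest, and both gaps lie beyond the scatter.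

Compound 4 `CC1=NN(S(=O)(=O)c2ccccc2C)C(c2cc(Br)ccc2O)C1` has not yet been measured in this assay and is the next point of interest. The change from compound 3 is methyl in place of hydrogen on an aromatic carbon and reads in words as methyl in place of hydrogen on an aromatic carbon, or phenyl to 2-methylphenyl.

Going by the values given here, no measured pair differs in one place only, so the data give no direct size for this change. Among the compounds with values here, compound 3 at 55600 nM is the only measured compound carrying the group that changes, and the expectation is anchored on it. A single added methyl is expected to give no shift beyond the scatter, in either direction. The expected step of a 1.2-fold lower number from compound 3 to compound 4 (0.06 log units; within the scatter) is an estimate and stays within the scatter. The estimated value for compound 4 is 48000 nM with an expected range from 20000 nM to 110000 nM for this measurement.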

Compound 4, half-maximal effective concentration: 48100 nM
Beside the measured number, compound 4's estimate is 1.0-fold (0.00 log units) below it; the range from low to high includes it.
By their numbers in this assay, from the lowest: compound 1; then compound 2; then compounds 4 and 3 (each within the scatter of the next).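

In this assay the series gets its first comparison that differs in one place only: methyl in place of hydrogen on an aromatic carbon, ortho to a large group, gives a 1.2-fold lower number from compound 3 to compound 4 (0.06 log units; within the scatter) and so sets a size for this change. At this position of the phenyl group, a single methyl is therefore accommodated with no readable effect on the antiproliferative read-out, and the pair supports no claim of a gain or a loss. No separate measurement bears on this result, so the data offer no account of why the step is this small.

A single methyl at a single place says little about how far this position tolerates change, and an amine, a carboxylic acid or a longer chain such as propyl on the same aromatic carbon could behave quite differently. Going by these compounds, it also remains open whether a methyl on another aromatic carbon of this phenyl group, or on the bromo-substituted hydroxyphenyl group of the shared core, would likewise stay within the scatter.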